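The source may report more compounds than this note shows. Statements on the series, on what has been measured and on what is new or still open speak of the compounds shown alone.

Working notes on the series in a functional assay on DU-145 cells (Homo sapiens) for cytotoxicity, read by CCK-8 assay; a higher number here means a weaker inhibitor, a lower number a stronger inhibitor.

Compound 1 `Oc1cccc(-c2cc(-c3ccsc3)cc(-c3cccc(O)c3)n2)c1` gives 1310 nM in this assay. Among the measured compounds shown here, compound 2 `Oc1ccc(-c2cc(-c3ccsc3)cc(-c3cccc(O)c3)n2)cc1` gives 2230 nM, the highest of the three numbers so far; its nearest neighbour is compound 3 `Oc1ccc(-c2cc(-c3ccsc3)cc(-c3ccc(O)cc3)n2)cc1`, which gives 2060 nM, and the furthest is compound 1. Both of the steps that link the measured compounds involve a 4-hydroxyphenyl in place of a 3-hydroxyphenyl on an aromatic carbon: a 1.7-fold higher number from compound 1 to compound 2 (0.23 log units; within the scatter) and a 1.1-fold lower number from compound 2 to compound 3 (0.03 log units; within the scatter). Neither of them leaves the scatter, so the series as measured shows no movement that can be read as a trend.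

Compound 4 `Oc1ccc(-c2cc(-c3cccnc3)cc(-c3cccc(O)c3)n2)cc1` differs from compound 2 in one place: pyridin-3-yl in place of thiophen-3-yl on an aromatic carbon. For the measured compounds named here, no measured step touches the thiophen-3-yl position, so the two hydroxyphenyl steps bear on it only in the general sense that small aromatic swaps on the shared core have so far left this assay unchanged beyond the scatter. On that basis no step beyond the scatter is expected in either direction for a 1.0-fold lower number from compound 2 to compound 4 (0.01 log units; within the scatter), with a wider range than usual since the change is of a new kind. Compound 4 is therefore expected to give 2200 nM in this assay, within 900 nM to 5500 nM.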

Compound 4, half-maximal inhibitory concentration: 6390 nM
For compound 4 the middle estimate is 2.9-fold (0.46 log units) below the measured one, and the stated range ends below it.
By their numbers in this assay, from the lowest: compounds 1, 3 and 2 (each within the scatter of the next); then compound 4.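

Among the compounds shown here, the thiophen-3-yl position, opposite the ring nitrogen, is the first place where a single change leaves the scatter in this assay: pyridin-3-yl in place of thiophen-3-yl gives a 2.9-fold higher number from compound 2 to compound 4 (0.46 log units; beyond the scatter), a modest step towards a weaker inhibitor, whereas both hydroxyphenyl steps stayed within the scatter. The number in this assay therefore responds to the identity of the aromatic group at this position, even though the two groups match in hydrogen-bond donors, hydrogen-bond acceptors and net charge and differ in ring size, heavy atoms and hetero atom. For the compounds shown here, nothing at hand accounts for the step, and the single pair gives no explanation of it.

Open, on these data alone, is whether ring size or the hetero atom carries the step, a question that a phenyl or a furan-3-yl group at this position would help to separate. Also open, as far as these compounds go, is whether pyridin-3-yl gives a step of similar size on the hydroxyphenyl arrangements of compound 1 and compound 3.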